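Removing a Methyl from Two Bromoacyl Anilides

The source may report more compounds than this note shows. Statements on the series, on what has been measured and on what is new or still open speak of the compounds shown alone.

Four closely related compounds are compared in a functional assay on CCRF-CEM cells (Homo sapiens) for antiproliferative activity, read by trypan blue exclusion, with a stated time of 72 h; on this read-out higher numbers stand for weaker inhibition and lower numbers for stronger inhibition. Compound 1 `Cc1c(NC(=O)C(C)Br)cccc1C(=O)NC(N)=O` gives 480 nM. Compound 3 `Cc1c(NC(=O)CBr)cccc1C(=O)NC(N)=O` gives 1710 nM. The change that carries compound 1 to compound 3 is hydrogen in place of methyl on a saturated chain carbon bound to a bromine atom and a carbonyl carbon, and it made a step of a 3.6-fold higher number from compound 1 to compound 3 (0.55 log units; beyond the scatter). Compound 2 `Cc1ccc(NC(=O)C(C)Br)cc1C(=O)NC(N)=O` is built from the same atoms as compound 1, joined differently; the difference between the two cores is not broken down here. For compound 2 in this assay only a limit is reported, > 20000 nM, so no number is known for it. This is the limit of > 20000 nM in this assay, at which 1 of the 3 values shown sits. Compound 4 `Cc1ccc(NC(=O)CBr)cc1C(=O)NC(N)=O` has not yet been measured. It stands to compound 2 as compound 3 stands to compound 1: the change is hydrogen in place of methyl on a saturated chain carbon bound to a bromine atom and a carbonyl carbon, the same change at the same place. The measured step of a 3.6-fold higher number from compound 1 to compound 3 (0.55 log units; beyond the scatter) went to a higher number, so the matching change is not expected to bring compound 4 into the measurable range. The step from compound 2 to compound 4 is estimated as a step that the limit leaves unreadable from compound 2 to compound 4. Compound 4 is thus estimated at 50000 nM, likely between 15000 nM and 200000 nM, and most probably this assay will again report only a limit for compound 4.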

Compound 4, half-maximal inhibitory concentration: 4760 nM
Beside the measured number, compound 4's estimate is 11-fold (1.02 log units) above it; measured number below the stated range.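

In this assay, the change from 1-bromoethyl to bromomethyl gives a 3.6-fold higher number from compound 1 to compound 3 (0.55 log units; beyond the scatter) on one core but an at least 4.2-fold lower number from compound 2 to compound 4 (0.62 log units; beyond the scatter) on the other, so on these two cores the effect of this change does not carry over, not even in its direction: the same change on two cores in this assay, a 3.6-fold higher number (0.55 log units; beyond the scatter) from compound 1 to compound 3 and an at least 4.2-fold lower number (0.62 log units; beyond the scatter) from compound 2 to compound 4, at least 14-fold (1.17 log units) apart, beyond the scatter of two such steps

From the compounds shown here alone, compound 2 has only a limit, > 20000 nM, so the true size of the step that starts from it stays unknown.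

The two pairs show that, here, the outcome of removing this methyl depends on the core it is removed from, but they do not show why, and two pairs cannot set a rule for a wider series.

Going by these compounds, it remains open whether the two cores would also part ways if chlorine took the place of the bromine, or if a longer chain took the place of the 1-bromoethyl group. Also open, on these data alone, is how an amine or a carboxylic acid in place of the bromine would read in this assay.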